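Aryl hydrazone variation at the imine carbon

A few compounds are considered here, and "the series" means these few. Any claim that something is new, unique, unknown or untested is made for them only; others in the source may bear on it.

Measured so far:
Compound 1, `O=C(N/N=C/c1ccccc1)c1cccnc1Nc1cccc(C(F)(F)F)c1`: 36.8%
Compound 2, `O=C(N/N=C/c1ccc(O)cc1)c1cccnc1Nc1cccc(C(F)(F)F)c1`: 68%
Compound 3, `COc1cccc(/C=N/NC(=O)c2cccnc2Nc2cccc(C(F)(F)F)c2)c1`: 49.7%

These three compounds share one core and differ only in the aryl group attached to the carbon with a double bond to nitrogen. In a functional assay on the whole organism (strain Wistar) for inhibition, with Rattus norvegicus as the target, read by paw edema, with a stated time of 2 h, at a dose of 10 mg/kg by the intraperitoneal route (on this read-out lower numbers stand for less inhibition and higher numbers for more inhibition at the one dose given (going by the name of the read-out)), compound 3 stands second highest of the three numbers. Its nearest neighbour is compound 1, and the step of a number 12.9 percentage points higher from compound 1 to compound 3 (beyond the scatter). Its furthest neighbour is compound 2, and the step of a number 18.3 percentage points lower from compound 2 to compound 3 (beyond the scatter). The largest move in the set is a number 31.2 percentage points higher from compound 1 to compound 2 (beyond the scatter).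

Compound 4 is `CN(C)c1ccc(/C=N/NC(=O)c2cccnc2Nc2cccc(C(F)(F)F)c2)cc1`. It has not yet been measured. The change from compound 3 is 4-(dimethylamino)phenyl in place of 3-methoxyphenyl on a carbon with a double bond to nitrogen. Among the compounds with values here, the step that bears on it most directly is the one from compound 2 to compound 3, since it also swaps the whole aryl group at the same place and was modest in size. The steps from compound 1 to compound 2 and from compound 1 to compound 3 show that adding a group to that ring has so far raised the number, by a large and by a modest amount. Within the data shown here, with only three compounds, the direction for a 4-(dimethylamino)phenyl group cannot be read off cleanly, so a small step in either direction is expected; the estimate is a number 4.3 percentage points higher from compound 3 to compound 4 (within the scatter). For compound 4 in this assay the expected value is 54%, with a range from 38% to 70%.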

Compound 4, a percentage reported as inhibition, in the whole organism at one dose (the size of the read-out at that dose, not a potency): 51.4%
Compound 4: middle estimate off by 2.6 percentage points, on the high side; measured number inside the range.
By their numbers in this assay, from the lowest: compound 1; then compounds 3 and 4 (each within the scatter of the next); then compound 2.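

In this assay the 4-(dimethylamino)phenyl group and the 3-methoxyphenyl group cannot be told apart, with a number 1.7 percentage points higher from compound 3 to compound 4 (within the scatter), even though this swap changes both the group on the ring and where it sits. The hydroxy group of compound 2 keeps its separate standing, since replacing it with dimethylamino gives a number 16.6 percentage points lower from compound 2 to compound 4 (beyond the scatter), while the same group in place of hydrogen gives a number 14.6 percentage points higher from compound 1 to compound 4 (beyond the scatter), so compound 4 becomes a third compound with a substituted ring that stands beyond the scatter above the plain phenyl ring of compound 1, and none of the compounds shown goes against this. Nothing measured here explains why the hydroxy compound stands apart from the other two substituted compounds.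

Because each group appears at only one place on the ring, the compounds shown cannot separate the effect of the group from the effect of its place, which a 4-methoxyphenyl or a 3-hydroxyphenyl group at the carbon with a double bond to nitrogen could begin to do. As far as these compounds go, whether a primary amine or a carboxylic acid on that ring would match compound 2 also stays open, and a single dose says nothing about potency.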